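The source may report more compounds than this note shows. Statements on the series, on what has been measured and on what is new or still open speak of the compounds shown alone.

Compound 1 `CN1C(=S)[C@@H](NC(=O)c2n[nH]c(Cc3ccccc3)n2)COc2ccccc21` and compound 2 `COCCn1nc(C(=O)N[C@H]2COc3ccccc3N(C)C2=S)nc1Cc1ccccc1` share a core, and compound 3 `CN1C(=S)[C@@H](NC(=O)c2nc(Cc3ccccc3)n(CCCO)n2)COc2ccccc21` is still to be measured in a toxicity assay on HT-29 cells (Homo sapiens) for cytotoxicity; on this read-out higher numbers stand for lower toxicity in this test and lower numbers for higher toxicity in this test. In this assay compound 1 gives > 50000 nM, which is a limit of the assay and not a number. Compound 2 gives > 100000 nM, which is also a limit and not a number. Compound 2 therefore has no exact value and cannot be ranked precisely. Among the compounds with values here, the only measured step, a step that the two limits leave unreadable from compound 1 to compound 2, places 2-methoxyethyl in place of hydrogen on an aromatic nitrogen.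

Compound 3 has the same atoms as compound 2, joined differently: hydroxymethyl in place of methoxy on a saturated chain carbon, two bonds along the chain from an aromatic nitrogen. This puts hydroxymethyl in place of methoxy on a saturated chain carbon, two bonds along the chain from an aromatic nitrogen, so 2-methoxyethyl becomes 3-hydroxypropyl. Within the data shown here, no measured step covers this exchange, and the one available step has no readable size. The expectation therefore rests on the limits of the two measured compounds. In this assay, the expected step is a number no higher from compound 2 to compound 3 (the limit leaves the size open), with no direction expected and nothing beyond the usual scatter. Compound 3 is estimated at 100000 nM, with an expected range from 40000 nM to 200000 nM.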

Compound 3, half-maximal cytotoxic concentration: > 100000 nM
Compound 3 was reported as a limit; the forecaster's own chance of this, stated with the estimate: 90%; the middle value lies on the limit itself.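

In this assay compound 3 gives > 100000 nM, which is a limit of the assay and not a number. The steps to compound 3 from compound 1 and from compound 2 therefore cannot be read. The compounds shown leave open what exact value any of them has in this assay, and whether these three differ at all.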